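Swapping a Pyrimidinylpiperazine for a Dimethylpiperidine

A few compounds are considered here, and "the series" means these few. Any claim that something is new, unique, unknown or untested is made for them only; others in the source may bear on it.

Compound 2 `N#Cc1ccc(Nc2nc(Oc3ccnc4ccccc34)nc(N3CCN(c4ncccn4)CC3)n2)cc1C(F)(F)F` sits at the edge of what the test can see: in a functional assay on DU-145 cells (Homo sapiens) for cytotoxicity, read by sulforhodamine B assay, with a stated time of 48 h (on this read-out lower numbers stand for higher toxicity in this test and higher numbers for lower toxicity in this test), compound 2 gives > 100000 nM, which is a limit of the test and not a number. Compound 1 `N#Cc1ccc(Nc2nc(Oc3ccnc4ccccc34)nc(N3CCCCC3)n2)cc1C(F)(F)F` also reaches only a limit, > 100000 nM. Compound 3 `N#Cc1ccc(Nc2nc(Oc3ccnc4ccccc34)nc(N3CCN(c4cccc(Cl)c4Cl)CC3)n2)cc1C(F)(F)F` likewise gives a limit, > 100000 nM. The two measured steps, a step that the two limits leave unreadable from compound 1 to compound 2 and a step that the two limits leave unreadable from compound 2 to compound 3, therefore cannot be sized because of the limit of > 100000 nM in this assay, at which 3 of the 3 values shown sit. Compound 4 `CC1CC(C)CN(c2nc(Nc3ccc(C#N)c(C(F)(F)F)c3)nc(Oc3ccnc4ccccc34)n2)C1` differs from compound 2 in one place: 3,5-dimethylpiperidin-1-yl in place of 4-(pyrimidin-2-yl)piperazin-1-yl on an aromatic carbon. Among the measured compounds shown here, no measured step gives a direction for this change. Compound 4 is therefore expected to remain at the limit as well, with an expected step that the limit leaves unreadable from compound 2 to compound 4. The estimate for compound 4 is 150000 nM, with a range from 50000 nM to 500000 nM.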

Compound 4, concentration lethal to 50% of the cells: > 100000 nM
Compound 4: only a limit was reported (the forecaster's own chance of this, stated with the estimate: 85%); the middle value does not contradict the limit.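

No new step can be read from compound 4 to compound 1 or compound 2, because all three stop at the same limit of the test: the limit of > 100000 nM in this assay, at which 4 of the 4 values shown sit.

The compounds shown leave open whether exchanging these groups on the shared core changes toxicity at all.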